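A few compounds are considered here, and "the series" means these few. Any claim that something is new, unique, unknown or untested is made for them only; others in the source may bear on it.

Compound 1 `c1ccc(-c2cc(-c3ccsc3)cc(-c3ccccn3)n2)nc1`, compound 2 `c1ccc(-c2cc(-c3ccccn3)nc(-c3ccccn3)c2)cc1` and compound 3 `c1ccc(-c2cc(-c3cccs3)cc(-c3ccncc3)n2)nc1` have been measured. In a functional assay on SK-OV-3 cells (Homo sapiens) for antiproliferative activity (on this read-out higher numbers stand for weaker inhibition of growth and lower numbers for stronger inhibition of growth), compound 1 gives 0.1 ug/mL, compound 2 gives 0.12 ug/mL and compound 3 gives 48.3 ug/mL. Compound 1 stands at the bottom of these numbers, though compound 2 lies within the scatter of it and cannot be told apart from it; compound 3 sits far above. Compound 4 `c1ccc(-c2cc(-c3ccsc3)cc(-c3cccnc3)n2)nc1` differs from compound 1 by pyridin-3-yl in place of pyridin-2-yl on an aromatic carbon. For the measured compounds named here, the only single measured step, a 1.2-fold higher number from compound 1 to compound 2 (0.08 log units; within the scatter), changes the thiophen-3-yl group and so says nothing about moving the pyridine nitrogen. Compound 3, which carries a pyridin-4-yl group, shows a much higher number than compound 1, but it also differs in its thiophene, so it gives only a hint. A sizeable loss is expected, a 50-fold higher number from compound 1 to compound 4 (1.70 log units; beyond the scatter). Compound 4 is estimated at 5 ug/mL, between 0.5 ug/mL and 50 ug/mL.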

Compound 4, concentration for 50% growth inhibition: > 100 ug/mL
Compound 4 ended at the assay's limit; the forecaster's own chance of this, stated with the estimate: 5%; middle value at least 20-fold (1.30 log units) away from the limit.
By their numbers in this assay, from the lowest: compounds 1 and 2 (each within the scatter of the next); then compound 3. At a limit, above all of these: compound 4.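

In this assay, pyridin-3-yl in place of pyridin-2-yl gives an at least 1000-fold higher number from compound 1 to compound 4 (3.00 log units; beyond the scatter). Compound 4 gives > 100 ug/mL, which is a limit of the assay and not a number. Growth inhibition by compound 1 thus depends strongly on where the nitrogen sits in this ring, something the only earlier single step could not show, as it changed the thiophen-3-yl group instead. Still open, going by these compounds, is how pyridin-4-yl alone would behave at this position. Also open, on these data alone, is whether an amine or a carboxylic acid on the pyridin-2-yl ring would keep the number low.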